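Opening a Seven-Membered Ring into an Acid Chain

The source may report more compounds than this note shows. Statements on the series, on what has been measured and on what is new or still open speak of the compounds shown alone.

Three measured compounds share one core. Compound 1 `COc1cnc(-c2ccccn2)nc1N(C)C1CCCC1` gives 180 nM in a functional assay on RAW264.7 cells (Mus musculus), with a stated time of 3 days (on this read-out higher numbers stand for weaker inhibition and lower numbers for stronger inhibition), and compound 2 `COc1cnc(-c2ccccn2)nc1NCc1ccccc1C(F)(F)F` gives 230 nM in this assay. Compound 3 `COc1cnc(-c2ccccn2)nc1N1CCCCCC1` gives 690 nM in this assay, the highest of the three numbers, with compound 2 closer to it and compound 1 furthest away. Within the data shown here, the only measured step at this position, a 3.8-fold higher number from compound 1 to compound 3 (0.58 log units; beyond the scatter), is modest. Compound 4 `COc1cnc(-c2ccccn2)nc1NCCCC(=O)O` differs from compound 3 by (3-carboxypropyl)amino in place of azepan-1-yl on an aromatic carbon. Among the measured compounds shown here, no measured compound carries anything like the (3-carboxypropyl)amino group, so guidance is loose, though compound 2 shows an open-chain amine sitting in the same range as the two rings. Compound 4 is therefore expected near 1200 nM, between 250 nM and 6000 nM. That estimate means a step of a 1.7-fold higher number from compound 3 to compound 4 (0.24 log units; within the scatter), toward a somewhat weaker result.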

Compound 4, half-maximal inhibitory concentration: > 10000 nM
Compound 4: no number, only a limit; the forecaster's own chance of this, stated with the estimate: 15%; middle value at least 8.3-fold (0.92 log units) away from the limit.
By their numbers in this assay, from the lowest: compounds 1 and 2 (each within the scatter of the next); then compound 3. At a limit, above all of these: compound 4.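

Compound 4 gives no number, only a limit: the limit of > 10000 nM in this assay, at which 1 of the 4 values shown sits.

Among these compounds, this position had so far shifted the number only modestly, whereas the acid chain brings an at least 14-fold higher number from compound 3 to compound 4 (1.16 log units; beyond the scatter) and an at least 55-fold higher number from compound 1 to compound 4 (1.74 log units; beyond the scatter). An open chain alone does not settle the outcome, as compound 2 also carries an open-chain amine and gives 230 nM.

The compounds shown leave open whether the carboxylic acid or the chain around it matters more. A methyl ester, a primary amide, or a shorter or longer acid chain at this position would help separate the two.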